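Working notes on the change from compound 3 to compound 4

The compounds below may be only part of what the source reports. "The series", "measured", "known", "first", "only" and "open" are said of these compounds alone.

Measured in a functional assay on HeLa cells (Homo sapiens) for inhibition, read by MTT assay, with a stated time of 24 h; a higher number here means a weaker inhibitor, a lower number a stronger inhibitor:
compound 1, `CCOC(=O)C1=Cc2ccccc2OC1(OCc1cn(CC(=O)NC2CCCCC2)nn1)C(F)(F)F`: 11400 nM
compound 2, `CCOC(=O)C1=Cc2ccccc2OC1(OCc1cc(-c2ccc3ccccc3c2)no1)C(F)(F)F`: a limit, > 150000 nM
compound 3, `O=C(O)C1=Cc2ccccc2OC1(OCc1cc(-c2ccc3ccccc3c2)no1)C(F)(F)F`: a limit, > 150000 nM

Compound 3 stands at a limit of this assay and not at a number; it shares that position with one further value in the set (the limit of > 150000 nM in this assay, at which 2 of the 3 values shown sit). For the measured compounds named here, only one step between measured compounds that differ in a single place is on record, a step that the two limits leave unreadable from compound 2 to compound 3, and the two limits leave it unreadable. Going by the values given here, compound 1 is the only member with a number, but it differs from compound 3 in more than one place, so no step to compound 3 can be read from it.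

The change to compound 4, `O=C(O)C1=Cc2ccccc2OC1(OCc1cc(-c2ccc(F)cc2)no1)C(F)(F)F`, is 4-fluorophenyl in place of naphthalen-2-yl on an aromatic carbon. Among the compounds with values here, no measured step touches the group on that aromatic carbon; the only recorded step concerns hydrogen in place of ethyl on an oxygen next to a carbonyl group, and it is unreadable. The expectation for compound 4 therefore rests on nothing more than the position of compound 3 at the limit. Compound 4 is estimated at 120000 nM in this assay, with a range of 30000 nM to 300000 nM. The step of an at least 1.2-fold lower number from compound 3 to compound 4 (0.09 log units; that floor lies within the scatter) is expected, with a limit again the likelier outcome for compound 4.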

Compound 4, half-maximal inhibitory concentration: > 150000 nM
Compound 4 ended at the assay's limit; the forecaster's own chance of this, stated with the estimate: 60%; at least 1.2-fold (0.09 log units) between middle value and limit.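

In this assay compound 4 gives > 150000 nM, a limit and not a number, and compound 3 also stands at a limit, so no step between compound 3 and compound 4 can be read: the limit of > 150000 nM in this assay, at which 3 of the 4 values shown sit.

The compounds shown leave open whether 4-fluorophenyl and naphthalen-2-yl on that aromatic carbon differ at all in this assay.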